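From pyridin-4-yl to 4-bromophenyl in compound 4

The source may report more compounds than this note shows. Statements on the series, on what has been measured and on what is new or still open speak of the compounds shown alone.

Three compounds have values so far in a functional assay on WM-115 cells (Homo sapiens) for cytotoxicity, read by MTT assay, with a stated time of 46 h (a higher number here means a weaker inhibitor, a lower number a stronger inhibitor), and they read:

Compound 1 `O=C1/C(=C/c2ccncc2)C(c2ccccc2)Oc2ccccc21` gives 6300 nM
Compound 2 `O=C1/C(=C\c2ccncc2)C(c2ccccc2)Oc2ccccc21` gives 4600 nM
Compound 3 `O=C1/C(=C/c2ccccc2)C(c2ccccc2)Oc2ccc(O)cc21` gives 44500 nM

Compound 2 and compound 1 lie within the scatter of each other, and compound 3 has a clearly higher number than either. Compound 2 therefore stands in the lower pair, not alone at the low end.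

Compound 4 `O=C1/C(=C\c2ccc(Br)cc2)C(c2ccccc2)Oc2ccccc21` carries 4-bromophenyl in place of pyridin-4-yl on a double-bonded chain carbon bound to a double-bonded ring carbon, and the count of that change is 4-bromophenyl in place of pyridin-4-yl on a double-bonded chain carbon bound to a double-bonded ring carbon in full.

For the measured compounds named here, the only measured step is a 1.4-fold lower number from compound 1 to compound 2 (0.14 log units; within the scatter) and it leaves this group untouched, with the fact that one of compounds 1 and 2 is drawn with a defined configuration and the other without, at the place where they differ limiting how firmly it can be read. Going by the values given here, no measured step exchanges the group, so no step beyond the scatter is expected in this assay in either direction, and the range must stay wide. The starting point is compound 2 at 4600 nM as measured. The expected change is a 1.1-fold higher number from compound 2 to compound 4 (0.04 log units; within the scatter) by this estimate. For compound 4 the estimated value is 5000 nM and the expected range runs from 1500 nM to 17000 nM in this assay.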

Compound 4, half-maximal inhibitory concentration: 32600 nM
Compound 4: the middle estimate sits 6.5-fold (0.81 log units) below what was measured; measured number above the stated range.
By their numbers in this assay, from the lowest: compounds 2 and 1 (each within the scatter of the next); then compounds 4 and 3 (each within the scatter of the next).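

In this assay, the group on the double-bonded chain carbon bound to a double-bonded ring carbon proves not to be freely exchangeable: 4-bromophenyl in place of pyridin-4-yl gives a 7.1-fold higher number from compound 2 to compound 4 (0.85 log units; beyond the scatter), the only step shown that exchanges this group. The earlier pair had shown only a change in how the double bond is drawn, with the group itself kept, and that step, a 1.4-fold lower number from compound 1 to compound 2 (0.14 log units; within the scatter), gave no sign that this place matters for the read-out. The exchange removes a ring with one hetero atom and one hydrogen-bond acceptor and brings in a carbon-only ring carrying bromine, but nothing at hand shows which of these differences accounts for the step.

The compounds shown do not separate the loss of the ring nitrogen from the gain of the bromine, a question that an unsubstituted phenyl group at this place on the core of compound 2 would address. They also leave open how a 4-aminophenyl or 4-carboxyphenyl group would read here, and whether the step holds with the double bond drawn as in compound 1.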